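Replacing the benzyloxy group at the saturated ring carbon

The source may hold more compounds than are shown below. What is called first, only, known or untested is meant among the compounds shown, and "the series" means these compounds.

For the measured compounds named here, compound 1 `Cc1nn(-c2ncnc3nc[nH]c23)c2c1C(OCc1ccccc1F)CC(=O)N2` gives 4 nM in a functional assay on HEK293 cells for agonist activity at G-protein coupled receptor 39 (Homo sapiens), read by scintillation proximity assay and inositol phosphate accumulation, with a stated time of 75 min, in the presence of a further agent that is not named here (a higher number here means that more compound is needed for the effect, a lower number that less compound is needed), the lowest of the three numbers measured so far. Compound 2 `Cc1nn(-c2ncnc3nc[nH]c23)c2c1C(OCc1ccccc1C#N)CC(=O)N2` gives 8 nM; the step is a 2.0-fold higher number from compound 1 to compound 2 (0.30 log units; within the scatter). Compound 3 `Cc1nn(-c2ncnc3nc[nH]c23)c2c1C(c1ccc(OC(C)C)cc1)CC(=O)N2` gives 18 nM; the step is a 4.5-fold higher number from compound 1 to compound 3 (0.65 log units; beyond the scatter), and the step from compound 2 is a 2.3-fold higher number from compound 2 to compound 3 (0.35 log units; beyond the scatter). Compound 4 `Cc1nn(-c2ncnc3nc[nH]c23)c2c1C(C(=O)N(C)c1ccccc1)CC(=O)N2` is still to be measured. The change is methyl(phenyl)carbamoyl in place of (2-fluorobenzyl)oxy on a saturated ring carbon. The step to compound 3 bears on it most, since there too the (2-fluorobenzyl)oxy group left the saturated ring carbon and the number rose beyond the scatter. Compound 4 is therefore expected to need more compound, with an estimated step of a 5.0-fold higher number from compound 1 to compound 4 (0.70 log units; beyond the scatter). The estimate for compound 4 is 20 nM, in a range from 5 nM to 80 nM.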

Compound 4, half-maximal effective concentration: 32 nM
For compound 4 the middle estimate is 1.6-fold (0.20 log units) below the measured one; the measured number falls inside the stated range.
By their numbers in this assay, from the lowest: compounds 1 and 2 (each within the scatter of the next); then compounds 3 and 4 (each within the scatter of the next).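

In this assay, a second replacement of the (2-fluorobenzyl)oxy group on the saturated ring carbon also raises the number (an 8.0-fold higher number from compound 1 to compound 4 (0.90 log units; beyond the scatter)), and the same holds against the (2-cyanobenzyl)oxy group (a 4.0-fold higher number from compound 2 to compound 4 (0.60 log units; beyond the scatter)). Methyl(phenyl)carbamoyl and 4-isopropoxyphenyl cannot be separated (a 1.8-fold higher number from compound 3 to compound 4 (0.25 log units; within the scatter)), so both replacements remain on the same level. Nothing available accounts for these steps. Going by these compounds, whether an amine or a carboxylic acid on this carbon would return the number towards that of compound 1 stays open, as does the effect of a longer chain there.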